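The source may report more compounds than this note shows. Statements on the series, on what has been measured and on what is new or still open speak of the compounds shown alone.

Of the compounds shown here, three have been tested so far, all built on one shared core. Compound 1 `CCC1(Cc2ccccc2)OS(=O)(=O)C=C1OC` carries a hydrogen on the saturated chain carbon bound to the oxygen on the unsaturated carbon, compound 2 `CCC1(Cc2ccccc2)OS(=O)(=O)C=C1OCc1ccc([N+](=O)[O-])cc1` carries a 4-nitrophenyl there, and compound 3 `CCC1(Cc2ccccc2)OS(=O)(=O)C=C1OCc1ccc(Cl)c(Cl)c1` carries a 3,4-dichlorophenyl. In an ADME assay on HEL cells (Homo sapiens) for cytotoxicity, with a stated time of 3 days (a higher number here means that more compound is tolerated, a lower number that less compound is tolerated), compound 1 gives > 400000 nM, which is a limit of the assay and not a number. Compound 2 gives >= 80000 nM in this assay, again a limit. Compound 3 gives >= 20000 nM in this assay, also a limit. Among the compounds with values here, because every value sits at a limit of > 400000 nM in this assay, at which 1 of the 3 values shown sits, the limit of >= 80000 nM in this assay, at which 1 of the 3 values shown sits (the limit of >= 20000 nM in this assay, at which 1 of the 3 values shown sits), none of the measured steps can be read: a step that the two limits leave unreadable from compound 1 to compound 2, a step that the two limits leave unreadable from compound 1 to compound 3 and a step that the two limits leave unreadable from compound 2 to compound 3 all remain of unknown size. Compound 2 therefore stands only as a limit among limits.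

Compound 4 `CCC1(Cc2ccccc2)OS(=O)(=O)C=C1OCc1ccc(C(C)(C)C)cc1` differs from compound 2 at a different place than any measured step: tert-butyl in place of nitro on an aromatic carbon. Within the data shown here, no measured step touches the aromatic carbon, so nothing in the data speaks to this change, and no step beyond the scatter is expected in this assay in either direction. Compound 4 is estimated at 80000 nM, within 20000 nM to 400000 nM, which means an expected step of a number no higher from compound 2 to compound 4 (the limit leaves the size open).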

Compound 4, minimum cytotoxic concentration: >= 400000 nM
Compound 4 ended at the assay's limit; the forecaster's own chance of this, stated with the estimate: 70%; at least 5.0-fold (0.69 log units) between middle value and limit.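

In this assay compound 4 gives >= 400000 nM, a limit of the assay and not a number. Compound 2 also stands only at a limit, and the step from compound 2 to compound 4 cannot be read. The compounds shown leave open how far tert-butyl in place of nitro shifts the tolerated concentration, or in which direction.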